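This account rests on a few compounds, and the source may have more. Where it says the series, first, only, none or still open, it means among the compounds named here.

Compound 3 `Cc1cc(N2CCN(C(=O)Nc3nc4ccc(F)cc4s3)CC2)nnc1Cl` stands in an assay on HEK293 cells for inhibition of transient receptor potential cation channel subfamily V member 1 (Homo sapiens), read by FLIPR (on this read-out lower numbers stand for stronger inhibition and higher numbers for weaker inhibition), only at the limit of the assay, giving > 10000 nM. Compound 1 `Cc1ccc(N2CCN(C(=O)Nc3nc4ccc(F)cc4s3)CC2)nn1` reaches the same limit, with > 10000 nM. Compound 2 `COc1ccc(N2CCN(C(=O)Nc3nc4ccc(F)cc4s3)CC2)nn1` likewise shows only the limit, at > 10000 nM. Compound 4 `O=C(Nc1nc2ccc(F)cc2s1)N1CCN(c2cccnn2)CC1` has not yet been measured. Its difference from compound 3 is this: pyridazin-3-yl in place of 6-chloro-5-methylpyridazin-3-yl on an amine nitrogen in a ring. The measured steps that bear on it are a step that the two limits leave unreadable from compound 1 to compound 2, a step that the two limits leave unreadable from compound 1 to compound 3 and a step that the two limits leave unreadable from compound 2 to compound 3, none of which can be sized because of the limit of > 10000 nM in this assay, at which 3 of the 3 values shown sit. No step beyond the scatter is therefore expected, and the expected step that the limit leaves unreadable from compound 3 to compound 4 rests on this alone. Compound 4 is estimated at 20000 nM, within a range from 5000 nM to 60000 nM, most likely again reported only as a limit.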

Compound 4, half-maximal inhibitory concentration: > 10000 nM
Compound 4 gave a limit, no number; the forecaster's own chance of this, stated with the estimate: 80%; the middle value lies beyond the limit too.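

No step among compound 1, compound 2, compound 3 and compound 4 can be read, because each gives only a limit: the limit of > 10000 nM in this assay, at which 4 of the 4 values shown sit.

The compounds shown leave open whether any group on the pyridazin-3-yl changes inhibition in this assay.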